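The source may report more compounds than this note shows. Statements on the series, on what has been measured and on what is new or still open speak of the compounds shown alone.

Working notes. In an assay on HEK293 cells for displacement of a labelled ligand from Orexin receptor type 2 (Homo sapiens), read by scintillation counting, with a stated time of 90 min (a higher number here means a weaker inhibitor, a lower number a stronger inhibitor), compound 2 `COc1cc(F)c(CN2C(=O)N(c3ccc(OC)c(OC)c3)S(=O)(=O)c3ccccc32)c(F)c1` gives 0.501 nM, the second highest of three numbers. Compound 1 `COc1cc(F)c(CN2C(=O)N(c3cc(OC)nc(OC)c3)S(=O)(=O)c3ccccc32)c(F)c1` gives 0.251 nM; the step of a 2.0-fold higher number from compound 1 to compound 2 (0.30 log units; within the scatter) is within the scatter. Compound 3 `COc1cc(N2C(=O)N(Cc3c(F)cc(F)cc3Cl)c3ccccc3S2(=O)=O)cnc1OC` gives 1.59 nM, a number beyond the scatter above compound 2, but no single-change comparison links compound 3 to the others.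

Compound 4 `COc1ccc(N2C(=O)N(Cc3ccccc3)c3ccccc3S2(=O)=O)cc1OC` carries phenyl in place of 2,6-difluoro-4-methoxyphenyl on a saturated chain carbon bound to an amide-type nitrogen in a ring. Among the measured compounds shown here, no measured step alters the benzyl group, so the only guide is that compound 3, with a different benzyl and a different aryl, sits higher than compound 2. A step toward a higher number in this assay is therefore expected, of size a 10-fold higher number from compound 2 to compound 4 (1.00 log units; beyond the scatter), with wide uncertainty. The estimate for compound 4 is 5 nM, within 1 nM to 25 nM.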

Compound 4, inhibition constant: 79.4 nM
Compound 4: the middle estimate sits 16-fold (1.20 log units) below what was measured; the measured number lies above the stated range.
By their numbers in this assay, from the lowest: compounds 1 and 2 (each within the scatter of the next); then compound 3; then compound 4.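

Among the compounds shown here, on a saturated chain carbon bound to an amide-type nitrogen in a ring, the change from 2,6-difluoro-4-methoxyphenyl to phenyl gives a 160-fold higher number from compound 2 to compound 4 (2.20 log units; beyond the scatter) in this assay, the first large single-change step. For the compounds shown here, the only earlier single-change step, made at a different substituent, stayed within the scatter. Nothing here explains the size of this step.

On these data alone, both fluorines and the methoxy leave together, so their separate contributions stay open. Also open, as far as these compounds go, is how a phenyl bearing a single fluorine, or a longer phenethyl chain, would read.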